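A few compounds are considered here, and "the series" means these few. Any claim that something is new, unique, unknown or untested is made for them only; others in the source may bear on it.

In a functional assay on A-431 cells (Homo sapiens) for inhibition, read by MTT assay, with a stated time of 72 h (on this read-out higher numbers stand for weaker inhibition and lower numbers for stronger inhibition), compound 1 `Brc1ccc(-c2nnc(SCCCN3CCN(c4nc5ccccc5o4)CC3)o2)cc1` gives 57800 nM, and compound 2 `Oc1ccc(-c2nnc(SCCCN3CCN(c4nc5ccccc5o4)CC3)o2)cc1` gives 117000 nM, the higher of the two numbers. Compound 3 `O=C(NCc1nnc(SCCCN2CCN(c3nc4ccccc4o3)CC2)o1)c1ccccc1` differs from compound 2 by one change: benzamidomethyl in place of 4-hydroxyphenyl on an aromatic carbon. Within the data shown here, the only measured step, hydroxy in place of bromo, is modest: a 2.0-fold higher number from compound 1 to compound 2 (0.31 log units; beyond the scatter). It bears on this larger replacement only loosely, so a modest move toward lower numbers is expected in this assay, perhaps none beyond the scatter. The expected change is a 1.5-fold lower number from compound 2 to compound 3 (0.17 log units; within the scatter). For compound 3 the estimated value is 80000 nM, with an expected range from 30000 nM to 200000 nM.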

Compound 3, half-maximal inhibitory concentration: 36900 nM
For compound 3 the middle estimate is 2.2-fold (0.34 log units) above the measured one; measured number inside the range.
By their numbers in this assay, from the lowest: compounds 3 and 1 (each within the scatter of the next); then compound 2.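

The 4-hydroxyphenyl group on this aromatic carbon, next to the ring nitrogen and the ring oxygen, is not needed for the activity seen in this assay: benzamidomethyl, a larger group, gives (a 3.2-fold lower number from compound 2 to compound 3 (0.50 log units; beyond the scatter)). Set against 4-bromophenyl, the same group gives (a 1.6-fold lower number from compound 1 to compound 3 (0.19 log units; within the scatter)), so a directly attached aromatic ring is not required here and benzamidomethyl is tolerated as well as 4-bromophenyl. Nothing measured here explains these results.

Going by these compounds, whether the amide contributes remains open, since a benzyl group at this carbon would separate it from the added length. On these data alone, how an amine or a carboxylic acid would behave at this position also remains open.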